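Inverting a single stereocentre in compound 3

The source may hold more compounds than are shown below. What is called first, only, known or untested is meant among the compounds shown, and "the series" means these compounds.

Measured so far in a functional assay on HeLa cells (Homo sapiens) for cytotoxicity, read by MTT assay, with a stated time of 48 h; on this read-out higher numbers stand for an effect only at larger amounts of compound and lower numbers for an effect already at smaller amounts:
compound 1, `CO[C@H]1O[C@H](COc2ccccc2C(C)C)[C@@H](O)[C@H](O)[C@H]1Oc1ccc(OC2CCCCC2)cc1`: 47000 nM
compound 2, `CO[C@H]1O[C@H](COc2ccc(C3CCCCC3)cc2)[C@@H](O)[C@H](O)[C@H]1Oc1ccc(OC2CCCCC2)cc1`: 10000 nM
compound 3, `CO[C@@H]1O[C@H](COc2cccc(C(C)C)c2)[C@@H](O)[C@H](O)[C@H]1Oc1ccc(OC2CCCCC2)cc1`: 39000 nM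

Among these three, compound 3 gives the second highest number. Compound 1 is its nearest neighbour, and the gap between them lies within the scatter, so the two cannot be told apart. Among the compounds with values here, compound 2 lies furthest away, with a lower number that is beyond the scatter; the only step measured between neighbours, a 4.7-fold lower number from compound 1 to compound 2 (0.67 log units; beyond the scatter), concerns a swap of one aryl group for another on an oxygen on a saturated carbon.

Compound 4, `CO[C@H]1O[C@H](COc2cccc(C(C)C)c2)[C@@H](O)[C@H](O)[C@H]1Oc1ccc(OC2CCCCC2)cc1`, is not yet measured. Its relation to compound 3 is the two compounds have the same atoms and bonds and differ only in configuration as drawn: 1 of 5 stereo elements differ; a stereocentre at a saturated ring carbon is drawn R in compound 3 and S in compound 4. Within the data shown here, no measured step involves a change in configuration alone, so the step from compound 3 to compound 4 has no direct precedent here. Compound 4 does share its drawn configuration at that centre with compound 1 and compound 2, which differ from it only in the aryl group carried on the saturated carbon.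

With nothing measured to point either way, the number for compound 4 is expected to stay close to that of compound 3, with a 1.1-fold lower number from compound 3 to compound 4 (0.05 log units; within the scatter) expected to fall within the scatter. The estimate for compound 4 in this assay is 35000 nM, with a range from 14000 nM to 85000 nM.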

Compound 4, half-maximal effective concentration: 28000 nM
For compound 4 the middle estimate is 1.3-fold (0.10 log units) above the measured one; the measured number falls inside the stated range.
By their numbers in this assay, from the lowest: compound 2; then compounds 4, 3 and 1 (each within the scatter of the next).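

In this assay, within the data shown here, the configuration at this saturated ring carbon is tested on its own for the first time, and the change from R to S gives a 1.4-fold lower number from compound 3 to compound 4 (0.14 log units; within the scatter), so this centre shows no effect that can be told from the scatter. Compound 4 also links the aryl groups within one drawn configuration: 3-isopropylphenyl in place of 2-isopropylphenyl gives a 1.7-fold lower number from compound 1 to compound 4 (0.22 log units; within the scatter), which also stays within the scatter, whereas 3-isopropylphenyl in place of 4-cyclohexylphenyl gives a 2.8-fold higher number from compound 2 to compound 4 (0.45 log units; beyond the scatter), which lies beyond it. The first step can be read as a change of configuration alone on one ground: the fact that compounds 3 and 4 differ only in the configuration as drawn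

The compounds shown leave open whether the same inversion would matter as little with 4-cyclohexylphenyl in place of 3-isopropylphenyl, or at any of the other stereocentres. On these data alone, it is also open how an amine or a carboxylic acid on this aryl group would behave.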